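A few compounds are considered here, and "the series" means these few. Any claim that something is new, unique, unknown or untested is made for them only; others in the source may bear on it.

Measured so far:
- compound 1, `O=S(=O)(NCCCNCc1ccc(Cl)c(Cl)c1)c1cc(C(F)(F)F)cc(C(F)(F)F)c1`: 2400 nM
- compound 2, `COc1ccc(CNCCCNS(=O)(=O)c2cc(C(F)(F)F)cc(C(F)(F)F)c2)cc1OC`: 1900 nM

Compound 2 stands at the lowest of the two numbers in a functional assay on MCF7 cells (Homo sapiens) for inhibition, read by MTT assay, with a stated time of 72 h; on this read-out lower numbers stand for stronger inhibition of growth and higher numbers for weaker inhibition of growth; its nearest neighbour is compound 1, and the step of a 1.3-fold lower number from compound 1 to compound 2 (0.10 log units; within the scatter) lies within the scatter, so the two cannot be ordered.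

Compound 3, `O=S(=O)(NCCCNCc1ccccc1)c1cc(C(F)(F)F)cc(C(F)(F)F)c1`, is not yet measured. Its difference from compound 2 is phenyl in place of 3,4-dimethoxyphenyl on a saturated chain carbon bound to an amine nitrogen.

For the measured compounds named here, the only measured step, a 1.3-fold lower number from compound 1 to compound 2 (0.10 log units; within the scatter), also changed the aryl group on that saturated chain carbon bound to an amine nitrogen, and it gave no change beyond the scatter. Going by the values given here, no step removing the two methoxy groups altogether is available. On that basis the step to compound 3 is expected to be small or absent, a 1.3-fold higher number from compound 2 to compound 3 (0.12 log units; within the scatter), with no clear direction.

For compound 3 in this assay the estimate is 2500 nM, expected within 1000 nM to 6500 nM.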

Compound 3, concentration for 50% growth inhibition: 3000 nM
For compound 3 the middle estimate is 1.2-fold (0.08 log units) below the measured one; the range from low to high includes it.
By their numbers in this assay, from the lowest: compounds 2, 1 and 3 (each within the scatter of the next).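

In this assay, the position on a saturated chain carbon bound to an amine nitrogen now has a plain phenyl compared directly with both substituted rings: a 1.6-fold higher number from compound 2 to compound 3 (0.20 log units; within the scatter) and a 1.3-fold higher number from compound 1 to compound 3 (0.10 log units; within the scatter). Taking away the two methoxy groups or the two chlorine atoms therefore gives no change that can be read, so 3,4-dimethoxyphenyl, 3,4-dichlorophenyl and phenyl cannot be told apart here, and the flat picture from the earlier pair now extends to the unsubstituted ring. Nothing available explains this lack of separation.

Open, as far as these compounds go, is whether any group at this position moves the number beyond the scatter, for example a naphthyl ring, a pyridine ring or a cyclohexyl ring in place of the phenyl. Also open, from the compounds shown here alone, is how a longer chain or an amide carbonyl at the amine nitrogen would read on the shared core.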